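Swapping the pyridine ring for phenyl on the amide

The source may report more compounds than this note shows. Statements on the series, on what has been measured and on what is new or still open speak of the compounds shown alone.

Measured so far:
Compound 1, `O=C(Nc1cc(C(F)(F)F)ccc1NC1CCCCC1)c1ccccc1`: "not active" (no number reported)
Compound 2, `O=C(Nc1cc(C(F)(F)F)ccc1Nc1ccc(Br)cc1)c1cccnc1Cl`: 35700 nM
Compound 3, `O=C(Nc1cc(C(F)(F)F)ccc1Nc1ccc(Br)cc1)c1ccncc1`: 51900 nM

In a functional assay on NALM-6 cells (Homo sapiens) for cytotoxicity, read by MTT assay, with a stated time of 48 h (on this read-out higher numbers stand for weaker inhibition and lower numbers for stronger inhibition), compound 3 gives 51900 nM, the highest of the two numbers; compound 2 gives 35700 nM, and the gap a 1.5-fold higher number from compound 2 to compound 3 (0.16 log units; within the scatter) is within the scatter. Compound 1 is reported only as "not active" (no number reported). Compound 4, `O=C(Nc1cc(C(F)(F)F)ccc1Nc1ccc(Br)cc1)c1ccccc1`, is not yet measured; it differs from compound 3 by phenyl in place of pyridin-4-yl on a carbonyl carbon. For the measured compounds named here, no measured step changes exactly this ring, so the only guide is the nearby step a 1.5-fold higher number from compound 2 to compound 3 (0.16 log units; within the scatter), which stayed within the scatter when the carbonyl ring was exchanged. A step within the scatter is therefore expected, with a real chance that the result is again reported as not active. Compound 4 is estimated at 55000 nM (range 20000 nM to 150000 nM), a step of a 1.1-fold higher number from compound 3 to compound 4 (0.03 log units; within the scatter) that is expected, not measured.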

Compound 4, half-maximal inhibitory concentration: 6000 nM
Compound 4: middle estimate off by 9.2-fold (0.96 log units), on the high side; the measured number lies below the stated range.
By their numbers in this assay, from the lowest: compound 4; then compounds 2 and 3 (each within the scatter of the next).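

The ring on the carbonyl carbon matters in this assay: the two pyridine rings stayed within the scatter of each other, yet phenyl in place of pyridin-4-yl gives an 8.7-fold lower number from compound 3 to compound 4 (0.94 log units; beyond the scatter), and phenyl in place of 2-chloropyridin-3-yl gives a 6.0-fold lower number from compound 2 to compound 4 (0.77 log units; beyond the scatter). Both steps lie beyond the scatter and both remove the ring nitrogen, although the second also removes the chlorine. Nothing measured here explains the change. Still open, going by these compounds, is whether a methoxy group or a fluorine on the phenyl ring would lower the number further.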